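This account rests on a few compounds, and the source may have more. Where it says the series, first, only, none or still open, it means among the compounds named here.

Measured so far in a functional assay on MCF7 cells (Homo sapiens) for inhibition, read by MTT assay, with a stated time of 24 h; a lower number here means a stronger inhibitor of growth, a higher number a weaker inhibitor of growth:
- compound 1 `COc1ccccc1C(=O)n1c(-c2cn(C)c3ccccc23)nc2ccccc21`: 32100 nM
- compound 2 `COc1ccc(C(=O)n2c(-c3cn(C)c4ccccc34)nc3ccccc32)cc1`: 16300 nM
- compound 3 `Cn1cc(-c2nc3ccccc3n2C(=O)c2cccc(Br)c2)c2ccccc21`: 63400 nM

Compound 1 holds the middle place of the three numbers, but neither of its steps clears the scatter: a 2.0-fold lower number from compound 1 to compound 2 (0.29 log units; within the scatter) and a 2.0-fold higher number from compound 1 to compound 3 (0.30 log units; within the scatter). Compound 4 `COc1ccc2c(c1)c(-c1nc3ccccc3n1C(=O)c1ccccc1OC)cn2C` keeps the 2-methoxyphenyl on the carbonyl carbon and differs from compound 1 by methoxy in place of hydrogen on an aromatic carbon.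

Among the measured compounds shown here, no measured step touches this place. All three change only the aryl group on the carbonyl carbon, so they bear on the new step indirectly, as a gauge of how far the series has moved. The largest, a 3.9-fold higher number from compound 2 to compound 3 (0.59 log units; beyond the scatter), is modest and the only one beyond the scatter. The effect of the added methoxy is therefore not shown by the data, and no step beyond the scatter is expected in this assay. The expected step is a 1.3-fold lower number from compound 1 to compound 4 (0.11 log units; within the scatter). For compound 4 the estimated value is 25000 nM, with an expected range of 9000 nM to 70000 nM.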

Compound 4, concentration for 50% growth inhibition: 23900 nM
Compound 4: the middle estimate sits 1.0-fold (0.02 log units) above what was measured; low and high end bracket the measured number.
By their numbers in this assay, from the lowest: compounds 2, 4, 1 and 3 (each within the scatter of the next, the first and the last beyond it).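

In this assay, methoxy in place of hydrogen on an aromatic carbon of the fused system is the only step shown that lies away from the aryl group on the carbonyl carbon. With a 1.3-fold lower number from compound 1 to compound 4 (0.13 log units; within the scatter), this place accepts the added methoxy without a change that can be told from the scatter. No measurement at hand accounts for this result or links it to any property of the group.

On these data alone, whether an amine or a carboxylic acid at this same place would also stay within the scatter of compound 1 remains open. Also open, as far as these compounds go, is whether the added methoxy would give a similar step alongside the 4-methoxyphenyl of compound 2 or the 3-bromophenyl of compound 3.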